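Swapping an Open Amino Acid Arm for a Ring

The source may report more compounds than this note shows. Statements on the series, on what has been measured and on what is new or still open speak of the compounds shown alone.

In a functional assay on MCF7 cells (Homo sapiens) for inhibition, read by MTT assay, with a stated time of 3 days (a lower number here means a stronger inhibitor, a higher number a weaker inhibitor), compound 1 `CC[C@H](C)[C@@H](NCC(=O)NNC(=O)COc1ccc(-c2nc3ccccc3s2)cc1OC)C(=O)O` gives 1790 nM. In the same test, compound 2 `COc1cc(-c2nc3ccccc3s2)ccc1OCC(=O)NNC(=O)CN[C@@H](CCSC)C(=O)O` gives 1950 nM, which places compound 2 level with compound 1, within the scatter. Compound 3 `COc1cc(-c2nc3ccccc3s2)ccc1OCC(=O)NNC(=O)CN1CCC[C@H]1C(=O)O` keeps the shared core but alters the arm: 2-carboxypyrrolidin-1-yl in place of (1-carboxy-3-(methylsulfanyl)propyl)amino on a saturated chain carbon bound to a carbonyl carbon. In words, 2-carboxypyrrolidin-1-yl stands in place of (1-carboxy-3-(methylsulfanyl)propyl)amino on a saturated chain carbon bound to a carbonyl carbon. For the measured compounds named here, only one measured step bears on this change: a 1.1-fold higher number from compound 1 to compound 2 (0.04 log units; within the scatter). Going by the values given here, that step exchanged one open side chain for another, and no measured compound carries the five-membered non-aromatic ring, so it is only a partial guide. The expected step, no larger than the scatter, is a 1.0-fold lower number from compound 2 to compound 3 (0.01 log units; within the scatter). In this assay, the estimate for compound 3 is 1900 nM, with an expected range of 800 nM to 4500 nM.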

Compound 3, half-maximal inhibitory concentration: 840 nM
Beside the measured number, compound 3's estimate is 2.3-fold (0.35 log units) above it, within the range that was stated.
By their numbers in this assay, from the lowest: compound 3; then compounds 1 and 2 (each within the scatter of the next).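

Exchanging one open side chain for another had left the number in this assay level, but the 2-carboxypyrrolidin-1-yl ring on this saturated chain carbon bound to a carbonyl carbon shifts it: the change gives (a 2.3-fold lower number from compound 2 to compound 3 (0.37 log units; beyond the scatter)) against the sulfur-bearing arm and (a 2.1-fold lower number from compound 1 to compound 3 (0.33 log units; beyond the scatter)) against the 1-carboxy-2-methylbutyl arm. Both steps are modest but beyond the scatter, so among these compounds the two open arms stand together and the ring stands apart from them. Nothing measured here gives a reason for this shift.

The compounds shown do not separate the effect of the ring itself from that of the carboxylic acid it carries. Going by these compounds, a plain pyrrolidin-1-yl or a 2-carboxypiperidin-1-yl at this place would test each of these, and how far the shift depends on the defined stereocentre also remains open.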